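A dichlorophenyl swap at the limit of the assay

This account rests on a few compounds, and the source may have more. Where it says the series, first, only, none or still open, it means among the compounds named here.

In a functional assay on MDA-MB-436 cells (Homo sapiens) for antiproliferative activity, read by MTT assay, with a stated time of 24 h (on this read-out lower numbers stand for stronger inhibition and higher numbers for weaker inhibition), compound 1 (`COc1ccc(C(=O)NC(CC(=O)O)c2ccc(C(C)(C)C)cc2)cc1`) gives > 100000 nM as a limit of the assay and not a number. Compound 2 (`CC(C)(C)c1ccc(C(CC(=O)O)NC(=O)c2c(Cl)cccc2Cl)cc1`) gives > 100000 nM and this too is a limit and not a number. Compound 2 therefore has no exact place on the scale, and the data show only the limit of > 100000 nM in this assay, at which 2 of the 2 values shown sit, for the pair. Compound 3 (`CC(C)(C)c1ccc(C(CC(=O)O)NC(=O)c2ccc(Cl)cc2Cl)cc1`) keeps the shared core and carries 2,4-dichlorophenyl in place of 2,6-dichlorophenyl on a carbonyl carbon. For the measured compounds named here, the only measured step at this place is a step that the two limits leave unreadable from compound 1 to compound 2 and it offers no size to carry over. No change beyond the usual scatter is therefore expected, and no direction can be predicted. The expected step is a number no higher from compound 2 to compound 3 (the limit leaves the size open) in this assay as well. For compound 3 the estimated value is 100000 nM with an expected range from 40000 nM to 250000 nM in this assay again.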

Compound 3, half-maximal inhibitory concentration: > 100000 nM
Compound 3: a limit, no number; the forecaster's own chance of this, stated with the estimate: 75%; the middle value lies on the limit itself.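

No new step can be read among compound 1, compound 2 and compound 3, since each result is a limit of the assay and not a number: the limit of > 100000 nM in this assay, at which 3 of the 3 values shown sit.

Left open is how strongly each compound acts in this assay and whether the group on the carbonyl carbon makes any difference there.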